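A few compounds are considered here, and "the series" means these few. Any claim that something is new, unique, unknown or untested is made for them only; others in the source may bear on it.

Compound 1 `CC1CCN(C2CCN(S(=O)(=O)c3cccc(N)c3)CC2)CC1` gives the highest of the three numbers in a functional assay on DLD-1 cells (Homo sapiens) for antiproliferative activity, read by CellTiter-Glo, with a stated time of 72 h (on this read-out higher numbers stand for weaker inhibition and lower numbers for stronger inhibition), at 3400 nM. Compound 2 `COc1ccccc1-c1cccc(S(=O)(=O)N2CCC(N3CCC(C)CC3)CC2)c1` gives 21 nM in this assay, and compound 3 `CC1CCN(C2CCN(S(=O)(=O)c3cccc(-c4ccccc4F)c3)CC2)CC1` gives 10 nM. The unmeasured compound 4 `CC1CCN(C2CCN(S(=O)(=O)c3ccc(F)cc3F)CC2)CC1` differs from compound 1 by 2,4-difluorophenyl in place of 3-aminophenyl on a sulfonyl sulfur. For the measured compounds named here, the steps that bear on this change are a 160-fold lower number from compound 1 to compound 2 (2.21 log units; beyond the scatter) and a 340-fold lower number from compound 1 to compound 3 (2.53 log units; beyond the scatter), both large; yet each of them put a second aromatic ring on the core, whereas compound 4 only swaps the amino for fluorines on a single ring, so a smaller gain is expected, that is a 2.8-fold lower number from compound 1 to compound 4 (0.45 log units; beyond the scatter). Compound 4 is therefore expected to give about 1200 nM, within 250 nM to 6000 nM.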

Compound 4, half-maximal inhibitory concentration: 102 nM
Compound 4: the middle estimate sits 12-fold (1.07 log units) above what was measured, outside the stated range (below it).
By their numbers in this assay, from the lowest: compound 3; then compound 2; then compound 4; then compound 1.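

In this assay, 2,4-difluorophenyl in place of 3-aminophenyl on the sulfonyl sulfur gives a 33-fold lower number from compound 1 to compound 4 (1.52 log units; beyond the scatter), so a large step at this position does not need a second aromatic ring on the core. A single fluorinated ring without the amino group is enough. Nothing measured here accounts for the size of this step. The compounds shown leave open whether one fluoro alone would give such a step, and whether an unsubstituted phenyl, a chloro or a nitrile on the ring would do the same.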